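The source may hold more compounds than are shown below. What is called first, only, known or untested is meant among the compounds shown, and "the series" means these compounds.

Compound 1 `Cn1c(-c2ccccc2C(F)(F)F)nnc1C12CCC(CCS(=O)(=O)C(C)(C)C)(CC1)CC2`: > 4000 nM
Compound 2 `Cn1c(-c2ccccc2C(F)(F)F)nnc1C12CCC(CNS(C)(=O)=O)(CC1)CC2`: > 4000 nM

In an assay on CHO-K1 cells for inhibition of 11-beta-hydroxysteroid dehydrogenase type 2 (Mus musculus), read by scintillation proximity assay (on this read-out higher numbers stand for weaker inhibition and lower numbers for stronger inhibition), compound 2 gives > 4000 nM, which is a limit of the assay and not a number. Compound 2 therefore stands at the limit, with nothing finer to place it. The account follows the change from compound 2 to compound 3 `Cn1c(-c2ccccc2C(F)(F)F)nnc1C12CCC(CCCC(C)(F)F)(CC1)CC2`, which has not yet been measured in this assay. The difference between the two structures is a group of 6 heavy atoms (4 carbon, 2 fluorine; no ring) in place of a group of 5 heavy atoms (1 carbon, 1 nitrogen, 2 oxygen, 1 sulfur; no ring), on a saturated chain carbon bound to a saturated ring carbon.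

Among the measured compounds shown here, only one measured step touches this position: a step that the two limits leave unreadable from compound 1 to compound 2, in which a methanesulfonamido group replaced a ((tert-butyl)sulfonyl)methyl group on the same saturated chain carbon. Its size cannot be read, because of the limit of > 4000 nM in this assay, at which 2 of the 2 values shown sit. Both measured compounds sit at that limit, so the data give no readable step and no direction for the position in question.

On this basis compound 3 is expected to remain near the limit as well, with the step from compound 2 to compound 3 estimated at a step that the limit leaves unreadable from compound 2 to compound 3. In this assay compound 3 is expected to give roughly 6000 nM, within a range from 1500 nM to 30000 nM.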

Compound 3, half-maximal inhibitory concentration: > 4000 nM
Compound 3: no number, only a limit (the forecaster's own chance of this, stated with the estimate: 75%); the middle value is on the limit's open side.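

In this assay compound 3 gives > 4000 nM, which is a limit of the assay and not a number. Among the compounds shown here, no step among compound 1, compound 2 and compound 3 can be read, because all three share one limit: the limit of > 4000 nM in this assay, at which 3 of the 3 values shown sit. The compounds shown leave open how strongly each of the three inhibits and whether the groups exchanged at this position differ at all.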